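Pyrrole in Place of Pyridine: A Single Ring Swap

The source may report more compounds than this note shows. Statements on the series, on what has been measured and on what is new or still open speak of the compounds shown alone.

Compound 1 `O=C(Nc1ccc(-c2cscn2)cc1)C1CCN(Cc2ccc(F)c(F)c2)C1`: 8000 nM
Compound 2 `O=C(Nc1ccc(-c2ccccn2)cc1)C1CCCN(Cc2ccc(F)c(F)c2)C1`: 11000 nM

Of the compounds shown here, two have been measured in a functional assay on A-375 cells (Homo sapiens) for activation, with a stated time of 3 days (on this read-out higher numbers stand for an effect only at larger amounts of compound and lower numbers for an effect already at smaller amounts), so far. Compound 1 gives 8000 nM and compound 2 gives 11000 nM. Compound 2 carries the higher of the two numbers, but its nearest neighbour is compound 1, and the gap between the two lies within the usual scatter, so the two values cannot be told apart.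

Compound 3 `O=C(Nc1ccc(-c2cc[nH]c2)cc1)C1CCCN(Cc2ccc(F)c(F)c2)C1` is the next compound and has not yet been measured in this assay. Compared with compound 2 it differs in one place: 1H-pyrrol-3-yl in place of pyridin-2-yl on an aromatic carbon. Going by the values given here, no step between two measured compounds is available that isolates this kind of change, so there is no internal yardstick for it.

Given that compound 2 gives 11000 nM and compound 1 gives a number within the scatter of it, the expectation for compound 3 is a step of a 1.1-fold lower number from compound 2 to compound 3 (0.04 log units; within the scatter) from compound 2, that is, no change beyond the scatter. Compound 3 is therefore estimated at 10000 nM, with a likely range from 3000 nM to 30000 nM.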

Compound 3, half-maximal effective concentration: 2610 nM
Compound 3: middle estimate off by 3.8-fold (0.58 log units), on the high side; measured number below the stated range.
By their numbers in this assay, from the lowest: compound 3; then compounds 1 and 2 (each within the scatter of the next).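

In this assay, the exchange of pyridin-2-yl for 1H-pyrrol-3-yl on an aromatic carbon, para to a large group, gives a 4.2-fold lower number from compound 2 to compound 3 (0.62 log units; beyond the scatter) and is the only step shown; because it lies beyond the scatter, it marks this position as one where a change of ring registers on the read-out. Going by these compounds alone, the single exchange alters several things at once: a six-membered aromatic ring with a hydrogen-bond acceptor leaves, and a five-membered aromatic ring with a hydrogen-bond donor enters. The step therefore cannot assign the lower number to ring size, to the donor or to the loss of the acceptor, and no measurement is available that explains the difference.

The compounds shown leave open whether the hydrogen on the pyrrole nitrogen matters, a question that a furan-3-yl group or a 1-methylpyrrol-3-yl group at the same place would address. They also leave open whether 1H-pyrrol-3-yl would bring a similar step on the core of compound 1.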